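Stretching a Long Chain to End in a Hydroxy Group

The source may report more compounds than this note shows. Statements on the series, on what has been measured and on what is new or still open speak of the compounds shown alone.

Three compounds share a core in which a catechol-bearing vinyl group is joined to a sulfonyl group, and differ only in what hangs from the sulfonyl. Compound 1 `CCCCCCCCCCCCS(=O)(=O)/C=C/c1ccc(O)c(O)c1` carries a long saturated chain; compound 2 `O=S(=O)(/C=C/c1ccc(O)c(O)c1)CC1CCCCC1` carries a cyclohexylmethyl group; compound 3 `CC(C)(C)OC(=O)N1CCCC1CS(=O)(=O)/C=C/c1ccc(O)c(O)c1` carries a protected pyrrolidine. In a functional assay, read by fluorescence and spectrophotometry, with a stated time of 1 h (on this read-out lower numbers stand for an effect already at smaller amounts and higher numbers for an effect only at larger amounts of compound), compound 1 gives 8500 nM, compound 2 gives 7500 nM, and compound 3 gives 7100 nM. Compound 1 gives the highest of the three numbers, but its gaps to compound 2 and to compound 3 are both within the usual scatter of this assay, so the three cannot be told apart on these data.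

Compound 4 `O=S(=O)(/C=C/c1ccc(O)c(O)c1)CCCCCCCCCCCO` is compound 1 with one change at the far end of its chain: hydroxy in place of methyl on a saturated chain carbon, ten or more bonds along the chain from a sulfonyl sulfur. Among the compounds with values here, no measured pair shows what such a change does here. With a change so far from the shared core, the step from compound 1 to compound 4 is expected to be small, and the estimate places compound 4 at 9000 nM, with a range from 4000 nM to 20000 nM, meaning an expected step of a 1.1-fold higher number from compound 1 to compound 4 (0.02 log units; within the scatter).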

Compound 4, half-maximal effective concentration: 22600 nM
Beside the measured number, compound 4's estimate is 2.5-fold (0.40 log units) below it; measured number above the stated range.
By their numbers in this assay, from the lowest: compounds 3, 2 and 1 (each within the scatter of the next); then compound 4.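

Hydroxy in place of methyl on a saturated chain carbon, along the chain from a sulfonyl sulfur, gives a 2.7-fold higher number from compound 1 to compound 4 (0.42 log units; beyond the scatter) in this assay, so compound 4 needs larger amounts of compound for its effect. Within the data shown here, a change this far along the chain can therefore still move the number beyond the usual scatter, something the earlier compounds could not show, as they differ from one another by whole groups and sit within the scatter of each other. Nothing available here explains why this swap has this effect.

As far as these compounds go, whether an amine or a carboxylic acid at this same place would move the number in the same direction remains open. So does whether a longer chain ending in hydroxy would give a step of similar size.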